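The compounds below may be only part of what the source reports. "The series", "measured", "known", "first", "only" and "open" are said of these compounds alone.

Values measured so far in a functional assay on PC-3 cells (Mus musculus) for cytotoxicity against PC-3 (Homo sapiens) (a lower number here means a stronger inhibitor, a higher number a weaker inhibitor), are these:

- compound 1 `CCCN(CCC)c1c([N+](=O)[O-])cc(S(=O)(=O)Nc2ccc(OC)cc2)cc1[N+](=O)[O-]` gives 31000 nM
- compound 2 `CCCN(CCC)c1c([N+](=O)[O-])cc(S(=O)(=O)Nc2cccc(OC)c2)cc1[N+](=O)[O-]` gives 36000 nM

On these numbers, compound 2 stands level with compound 1, within the scatter. Compound 3 `CCCN(CCC)c1c([N+](=O)[O-])cc(S(=O)(=O)Nc2cccc(C)c2)cc1[N+](=O)[O-]` differs from compound 2 by methyl in place of methoxy on an aromatic carbon, with methyl in place of methoxy on an aromatic carbon. Among the measured compounds shown here, only one measured step bears on this, and it swaps no group: a 1.2-fold higher number from compound 1 to compound 2 (0.06 log units; within the scatter) lies within the scatter. It is weak guidance, but no step beyond the scatter is expected in this assay. The expected change is a 1.2-fold lower number from compound 2 to compound 3 (0.08 log units; within the scatter). For compound 3 the estimated value is 30000 nM, with an expected range of 14000 nM to 65000 nM.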

Compound 3, half-maximal inhibitory concentration: 25000 nM
Compound 3: the middle estimate sits 1.2-fold (0.08 log units) above what was measured, within the range that was stated.
By their numbers in this assay, from the lowest: compounds 3, 1 and 2 (each within the scatter of the next).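

In this assay, the step to methyl gives a 1.4-fold lower number from compound 2 to compound 3 (0.16 log units; within the scatter), so losing the oxygen of methoxy, and with it a hydrogen-bond acceptor, leaves the reading level at this place on the ring. Changing both the group and its place, from 4-methoxyphenyl to 3-methylphenyl on the sulfonamide nitrogen, also gives only a 1.2-fold lower number from compound 1 to compound 3 (0.09 log units; within the scatter) for the pair. No measurement is at hand that would explain this. From the compounds shown here alone, whether an amine, a carboxylic acid or a longer chain here would move the number beyond the scatter stays open.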